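The compounds below may be only part of what the source reports. "The series", "measured", "known", "first", "only" and "open" are said of these compounds alone.

In an assay on isolated protein for displacement of a labelled ligand from melanin-concentrating hormone receptor 1 (Homo sapiens) (a higher number here means a weaker inhibitor, a lower number a stronger inhibitor), compound 3 `CCCc1cc(N)c2cc(NC(=O)/C=C/c3cccc(Cl)c3)ccc2n1` gives 1100 nM, the highest number of the three and, on the steps shown, the weakest binder of the set. Compound 1 `CCCc1cc(N)c2cc(NC(=O)/C=C/c3ccc(Cl)cc3)ccc2n1` gives 6 nM and compound 2 `CCCc1cc(N)c2cc(NC(=O)/C=C/c3ccc(CC)cc3)ccc2n1` gives 1.4 nM. The steps of a 180-fold higher number from compound 1 to compound 3 (2.26 log units; beyond the scatter) and a 790-fold higher number from compound 2 to compound 3 (2.90 log units; beyond the scatter) both put the 3-chlorophenyl far behind the 4-chlorophenyl and 4-ethylphenyl analogues, while the smaller step of a 4.3-fold lower number from compound 1 to compound 2 (0.63 log units; beyond the scatter) shows ethyl and chloro lying fairly close together. Compound 4 `CCCc1cc(N)c2cc(NC(=O)/C=C/c3ccc(Cl)c(Cl)c3)ccc2n1` carries chloro in place of hydrogen on an aromatic carbon, so it keeps the chloro of compound 3 and adds a chloro para to the large group, as compound 1 has. Going by the values given here, no measured pair isolates adding chloro onto a 3-chlorophenyl; the nearest guide is a 180-fold higher number from compound 1 to compound 3 (2.26 log units; beyond the scatter) read in reverse. Among the compounds with values here, the expected step is therefore large and toward a lower number, a 73-fold lower number from compound 3 to compound 4 (1.87 log units; beyond the scatter), though the retained chloro of compound 3 has no precedent here and may keep the number somewhat above that of compound 1. Compound 4 is estimated at 15 nM in this assay, with a range of 3 nM to 80 nM.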

Compound 4, half-maximal inhibitory concentration: 60 nM
Compound 4: middle estimate off by 4.0-fold (0.60 log units), on the low side, and the stated range covers the measured number.
By their numbers in this assay, from the lowest: compound 2; then compound 1; then compound 4; then compound 3.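

In this assay, chloro in place of hydrogen, para to a large group, restores much of the binding missing from the 3-chlorophenyl amide, with an 18-fold lower number from compound 3 to compound 4 (1.26 log units; beyond the scatter). The recovery is only partial: the 3,4-dichlorophenyl stays behind both single-substituted analogues, with a 10-fold higher number from compound 1 to compound 4 (1.00 log units; beyond the scatter) and a 43-fold higher number from compound 2 to compound 4 (1.63 log units; beyond the scatter), so the second chloro lowers binding even when the para chloro is present, though by less than a 180-fold higher number from compound 1 to compound 3 (2.26 log units; beyond the scatter). No measurement shown here accounts for these steps.

From the compounds shown here alone, whether this recovery needs chloro itself remains open, as a methoxy or an amine at the same place could behave differently. Also open, going by these compounds, is whether the 4-ethylphenyl of compound 2 would lose as much on taking the same added chloro.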